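Swapping an acid side chain for a branched alkyl

The source may report more compounds than this note shows. Statements on the series, on what has been measured and on what is new or still open speak of the compounds shown alone.

Of the compounds shown here, three sharing one core have been measured in a functional assay on the whole organism (Tail, strain ICR) with Mus musculus as the target, in the tail flick test, with a stated time of 150 min, at a dose of 25 umol/kg by the oral route; a lower number here means a weaker effect, a higher number a stronger effect of the compound at the dose given. Compound 1, `N=C(N)NCCC[C@H](NC(=O)CN(c1nc(Cl)nc2[nH]cnc12)C1CC1)C(=O)O`, gives 7.19%. Compound 2, `CC[C@H](C)[C@H](NC(=O)CN(c1nc(Cl)nc2[nH]cnc12)C1CC1)C(=O)O`, gives 6.71%. Compound 3, `O=C(O)C[C@H](NC(=O)CN(c1nc(Cl)nc2[nH]cnc12)C1CC1)C(=O)O`, gives 11.6%, the largest of the three numbers, though its steps to the others stay within the scatter: a number 4.4 percentage points higher from compound 1 to compound 3 (within the scatter) and a number 4.9 percentage points higher from compound 2 to compound 3 (within the scatter). The untested compound 4, `CC(C)C[C@H](NC(=O)CN(c1nc(Cl)nc2[nH]cnc12)C1CC1)C(=O)O`, differs from compound 3 by isopropyl in place of carboxy on a saturated chain carbon, two bonds along the chain from an amide-type nitrogen and a carbonyl carbon. For the measured compounds named here, the closest precedent is the step from compound 2 to compound 3, where carboxymethyl replaced sec-butyl with only a number 4.9 percentage points higher from compound 2 to compound 3 (within the scatter); the move to compound 4 runs the other way, from an acid-bearing side chain to a plain alkyl one, so compound 4 is expected to sit close to compound 2 and the step of a number 4.1 percentage points lower from compound 3 to compound 4 (within the scatter) is estimated to stay within the scatter. In this assay compound 4 is therefore expected to give about 7.5%, with a likely range from 2% to 14%.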

Compound 4, a percentage reported as activity, at one dose (the size of the read-out at that dose, not a potency): 9.13%
The estimate for compound 4 lay 1.6 percentage points below the measured number; the range from low to high includes it.
By their numbers in this assay, from the lowest: compounds 2, 1, 4 and 3 (each within the scatter of the next).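

In this assay, isopropyl in place of carboxy gives a number 2.5 percentage points lower from compound 3 to compound 4 (within the scatter) at this position, so removing the acid from this side chain leaves no change that can be told from the scatter. Isobutyl in place of sec-butyl gives a number 2.4 percentage points higher from compound 2 to compound 4 (within the scatter) on the same carbon, and replacing the group of 6 heavy atoms gives a number 1.9 percentage points higher from compound 1 to compound 4 (within the scatter) as the result, which places the plain alkyl, acid-bearing and nitrogen-bearing side chains within the scatter of one another. Nothing available explains these small steps.

As far as these compounds go, whether any side chain here can shift the read-out beyond the scatter remains open, and a benzyl group, a primary amine or a longer alkyl chain would each test this. From the compounds shown here alone, how these compounds compare at other doses or times also remains open.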